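Estimating the Pyrrolyl Analogue of Compound 1

The source may hold more compounds than are shown below. What is called first, only, known or untested is meant among the compounds shown, and "the series" means these compounds.

Compound 1 `COc1cc(/C=C/C(=O)c2ccccc2NC(=O)NS(=O)(=O)c2ccc(C)cc2)ccc1O`: 17.8 ug/mL
Compound 2 `Cc1ccc(S(=O)(=O)NC(=O)Nc2ccccc2C(=O)/C=C/c2ccc(Cl)cc2)cc1`: 6.92 ug/mL
Compound 3 `Cc1ccc(S(=O)(=O)NC(=O)Nc2ccccc2C(=O)/C=C/c2ccc(Cl)cc2Cl)cc1`: 8.34 ug/mL

In an ADME assay on the whole organism for cytotoxicity, with Artemia salina as the target, with a stated time of 24 h (a lower number here means that less compound is needed, a higher number that more compound is needed for the effect), compound 1 stands highest of the three numbers measured. Compound 4 `Cc1ccc(S(=O)(=O)NC(=O)Nc2ccccc2C(=O)/C=C/c2ccc[nH]2)cc1` differs from compound 1 in one place: 1H-pyrrol-2-yl in place of 4-hydroxy-3-methoxyphenyl on a double-bonded chain carbon bound to a double-bonded chain carbon. Among the compounds with values here, two measured steps bear on this change, since both also replace the same group at the same place: a 2.6-fold lower number from compound 1 to compound 2 (0.41 log units; beyond the scatter) and a 2.1-fold lower number from compound 1 to compound 3 (0.33 log units; beyond the scatter). Both lowered the number modestly, while a 1.2-fold higher number from compound 2 to compound 3 (0.08 log units; within the scatter). Neither step introduces a five-membered aromatic ring with one hetero atom, so the direction is carried over with caution and a smaller size is expected. Compound 4 is therefore estimated at 12 ug/mL, with a range of 5 ug/mL to 30 ug/mL. That estimate means a 1.5-fold lower number from compound 1 to compound 4 (0.17 log units; within the scatter).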

Compound 4, concentration for half-maximal effect: 32.1 ug/mL
The estimate for compound 4 lay 2.7-fold (0.43 log units) below the measured number; measured number above the stated range.
By their numbers in this assay, from the lowest: compounds 2 and 3 (each within the scatter of the next); then compounds 1 and 4 (each within the scatter of the next).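

In this assay the lowering seen with the two chlorine-bearing phenyl groups does not carry over to 1H-pyrrol-2-yl at this place: the change gives a 1.8-fold higher number from compound 1 to compound 4 (0.26 log units; within the scatter) and so no shift that can be told from scatter. Measured against those groups, 1H-pyrrol-2-yl gives a 3.8-fold higher number from compound 3 to compound 4 (0.59 log units; beyond the scatter) and a 4.6-fold higher number from compound 2 to compound 4 (0.67 log units; beyond the scatter) and so only the two chlorine-bearing compounds stand apart among the four. Nothing measured here accounts for this. The compounds shown leave open whether an unsubstituted phenyl or a pyridin-2-yl group at this place would fall with compounds 2 and 3 or with compounds 1 and 4.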